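A few compounds are considered here, and "the series" means these few. Any claim that something is new, unique, unknown or untested is made for them only; others in the source may bear on it.

In an ADME assay on microsomes (Homo sapiens) for metabolic stability (a higher number here means faster removal of the compound, a lower number slower removal), compound 1 (`CNC(=O)[C@@H]1CCCN1S(=O)(=O)c1ccc(Cl)c(COc2cccc3c(C(F)(F)F)cc(C)nc23)c1Cl`) gives 250 mL/min/kg, compound 2 (`CCc1cc(C(F)(F)F)c2cccc(OCc3c(Cl)ccc(S(=O)(=O)N4CCC[C@H]4C(=O)NC)c3Cl)c2n1`) gives 300 mL/min/kg and compound 3 (`Cc1cc(C(F)(F)F)c2cccc(OCc3c(Cl)ccc(S(=O)(=O)N4CCC[C@H]4C(N)=O)c3Cl)c2n1`) gives 167 mL/min/kg, so compound 3 sits within the scatter of both others. Compound 4 (`Cc1cc(C(F)(F)F)c2cccc(OCc3c(Cl)ccc(S(=O)(=O)N4CCC[C@H]4C(=O)O)c3Cl)c2n1`) has hydroxy in place of amino on a carbonyl carbon, turning carbamoyl into carboxy: hydroxy in place of amino on a carbonyl carbon. The closest evidence is a change on an amide-type nitrogen, a 1.5-fold lower number from compound 1 to compound 3 (0.18 log units; within the scatter). A change further from that group, a 1.2-fold higher number from compound 1 to compound 2 (0.08 log units; within the scatter), says less. Going by the values given here, no measured compound carries carboxy, so the size of this step remains uncertain. The expected result, a modest move towards slower removal, is a 1.9-fold lower number from compound 3 to compound 4 (0.27 log units; within the scatter). For compound 4 the estimated clearance is 90 mL/min/kg, with an expected range from 25 mL/min/kg to 200 mL/min/kg.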

Compound 4, clearance: 8.33 mL/min/kg
Beside the measured number, compound 4's estimate is 11-fold (1.03 log units) above it; measured number outside the range, below it.
By their numbers in this assay, from the lowest: compound 4; then compounds 3, 1 and 2 (each within the scatter of the next).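

In this assay the move to carboxy gives a 20-fold lower number from compound 3 to compound 4 (1.30 log units; beyond the scatter) when amino leaves and a 30-fold lower number from compound 1 to compound 4 (1.48 log units; beyond the scatter) when methylamino leaves, while the earlier change on the amide nitrogen stayed within the scatter. So this carbonyl carbon can matter greatly: the large drop appears with carboxy, not with either amide. Nothing measured here explains the drop.

On these data alone, whether a methyl ester or a hydroxamic acid at this carbon would give a similarly low number stays open, as does whether carboxy would act the same alongside the ethyl group of compound 2.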